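The source may report more compounds than this note shows. Statements on the series, on what has been measured and on what is new or still open speak of the compounds shown alone.

Series notes. Two compounds have been run in a functional assay, read by spectrophotometry, with a stated time of 30 min, tested at 10 uM (on this read-out lower numbers stand for a weaker effect and higher numbers for a stronger effect at the one concentration tested), so far. Compound 1 `COc1cc(/C=C/c2nc3cc(Cl)cnc3n(CC(=O)O)c2=O)ccc1O` gives 62.3% in this assay. Compound 2 `O=C(O)Cn1c(=O)c(/C=C/c2ccc(O)c(O)c2)nc2cc(Br)cnc21` gives 70.8% in this assay, the higher of the two numbers, though the gap to compound 1 is within the usual scatter, so the two cannot be ordered on these data.

The next compound, compound 3 `COc1cc(/C=C/c2nc3cc(Br)cnc3n(CC(=O)O)c2=O)ccc1O`, is the one whose read-out is not yet in hand. Compared with compound 2 it carries the change (methyl in place of hydrogen on an oxygen on an aromatic ring), that is hydroxy to methoxy, 3,4-dihydroxyphenyl to 4-hydroxy-3-methoxyphenyl, on the shared core. For the measured compounds named here, no step between two measured compounds covers this change, so nothing here fixes its direction. Both measured compounds sit in the same band, with compound 1 at 62.3% and compound 2 at 70.8%, so no step beyond the scatter is expected in this assay in either direction.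

For compound 3 the expected step is a number 6.8 percentage points lower from compound 2 to compound 3 (within the scatter). Compound 3 is therefore estimated at 64% in this assay, with a range from 50% to 78%.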

Compound 3, a percentage reported as activity, at one concentration (the size of the read-out at that concentration, not a potency): 59.6%
The estimate for compound 3 lay 4.4 percentage points above the measured number, within the range that was stated.
By their numbers in this assay, from the lowest: compounds 3, 1 and 2 (each within the scatter of the next, the first and the last beyond it).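

In this assay, for the compounds shown here, methyl in place of hydrogen on an oxygen on an aromatic ring, hydroxy to methoxy with the bromo held constant, gives a number 11.2 percentage points lower from compound 2 to compound 3 (beyond the scatter); this is the first single-place change to exceed the scatter, and it marks this oxygen as a place where a change registers on the read-out. Bromo in place of chloro on an aromatic carbon, with the 4-hydroxy-3-methoxyphenyl group held constant, gives a number 2.7 percentage points lower from compound 1 to compound 3 (within the scatter), so the read-out in this assay separates no effect of this halogen exchange. No measurement in hand speaks to the reason for either step.

The compounds shown leave open whether the hydroxy to methoxy step carries over to the chloro compounds, and whether an ethoxy group or a longer chain on the same oxygen, or an amine in place of the hydroxy, would give a step of similar size. Also open, as far as these compounds go, is how the read-out responds at other places on the shared core, for example with an amide in place of the carboxylic acid.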